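From phenyl to pyridin-2-yl on a shared core

The compounds below may be only part of what the source reports. "The series", "measured", "known", "first", "only" and "open" are said of these compounds alone.

In an ADME assay on MT4 cells (Homo sapiens) for cytotoxicity, read by MTT assay, with a stated time of 96 h (a higher number here means that more compound is tolerated, a lower number that less compound is tolerated), compound 1 (`CC(=O)c1ccc2[nH]c(-c3ccccc3)nc2c1`) has the entry "not determined" (no result reported) and so offers no number. Compound 2 (`COc1ccc(-c2nc3cc(/C(C)=N/NC(N)=O)ccc3[nH]2)c(OC)c1`) gives 21000 nM while compound 3 (`CC(=O)c1ccc2c(c1)nc(-c1ccccc1)n2C1CCCCC1`) gives 37000 nM and these two values lie within the usual scatter of each other. Compound 4 (`CC(=O)c1ccc2c(c1)nc(-c1ccccn1)n2C1CCCCC1`) has not been measured yet. Compared with compound 3, it carries pyridin-2-yl in place of phenyl on an aromatic carbon between two ring nitrogen atoms. Going by the values given here, no measured pair shows this swap, so the expectation rests on compound 3 at 37000 nM alone. The estimated step of a 1.1-fold lower number from compound 3 to compound 4 (0.05 log units; within the scatter) in this assay is expected to stay within the scatter. The estimate for compound 4 is 33000 nM within an expected range of 14000 nM to 80000 nM in the same measurement.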

Compound 4, half-maximal cytotoxic concentration: 70000 nM
Compound 4: middle estimate off by 2.1-fold (0.33 log units), on the low side; low and high end bracket the measured number.
By their numbers in this assay, from the lowest: compounds 2, 3 and 4 (each within the scatter of the next, the first and the last beyond it).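

In this assay, pyridin-2-yl in place of phenyl on the aromatic carbon gives a 1.9-fold higher number from compound 3 to compound 4 (0.28 log units; within the scatter), a step within the usual scatter. This position therefore takes a ring nitrogen, and with it a hydrogen-bond acceptor, without a clear shift in the tolerated concentration. No supporting data bear on why this is so.

Still open, as far as these compounds go, is whether a different group on this carbon, such as a carboxylic acid or an amine-bearing chain, would shift the number beyond the scatter. It is also unclear whether the same swap would behave alike without the cyclohexyl group.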